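Swapping the carbamate tail for an oxadiazole amide

This account rests on a few compounds, and the source may have more. Where it says the series, first, only, none or still open, it means among the compounds named here.

Compound 1 `Cc1nc(S(C)(=O)=O)ccc1Oc1ncnc(OC2CCN(C(=O)OC(C)F)CC2)c1F`: 65.5 nM
Compound 2 `Cc1nc(S(C)(=O)=O)ccc1Oc1ncnc(OC2CCN(C(=O)OC3(C(F)(F)F)CCC3)CC2)c1F`: 14.3 nM
Compound 3 `Cc1nc(S(C)(=O)=O)ccc1Oc1ncnc(OC2CCN(C(=O)C3CCCC3)CC2)c1F`: 72.8 nM

Of the compounds shown here, three sharing one core have been measured in a functional assay on isolated protein for inhibition of Glucose-dependent insulinotropic receptor (Homo sapiens), read by HTRF and cAMP accumulation; on this read-out lower numbers stand for an effect already at smaller amounts and higher numbers for an effect only at larger amounts of compound. Compound 1 and compound 3 sit close together, with a 1.1-fold higher number from compound 1 to compound 3 (0.05 log units; within the scatter) inside the usual scatter, while compound 2 gives a clearly lower number: a 4.6-fold lower number from compound 1 to compound 2 (0.66 log units; beyond the scatter). Compound 1 therefore stands in the upper part of the range, beside compound 3 and well away from compound 2.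

Compound 4 `Cc1nc(S(C)(=O)=O)ccc1Oc1ncnc(OC2CCN(C(=O)c3noc(C(C)C)n3)CC2)c1F` is not yet measured. Its change from compound 1 is a group of 8 heavy atoms (5 carbon, 2 nitrogen, 1 oxygen; one five-membered aromatic ring with 3 hetero atoms) in place of a group of 4 heavy atoms (2 carbon, 1 oxygen, 1 fluorine; no ring), on a carbonyl carbon. Two earlier steps bear on it, both altering the group on the same carbonyl carbon: the step to compound 3, which stayed within the scatter, and the step to compound 2, a modest gain when a larger group entered. Among the compounds with values here, the group entering in compound 4 is larger than what leaves, and so a modest lowering of the number is expected, though the ring and heteroatoms of the new group have no direct precedent here and widen the uncertainty. For compound 4 the expected step is a 2.2-fold lower number from compound 1 to compound 4 (0.34 log units; beyond the scatter). The estimated value for compound 4 is 30 nM, with a range from 8 nM to 120 nM.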

Compound 4, half-maximal effective concentration: 21.2 nM
Estimate against measurement, compound 4: 1.4-fold (0.15 log units) above; measured number inside the range.
By their numbers in this assay, from the lowest: compounds 2 and 4 (each within the scatter of the next); then compounds 1 and 3 (each within the scatter of the next).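

Within the data shown here, compound 3 gives the cleanest reading, since there the only change is 5-isopropyl-1,2,4-oxadiazol-3-yl in place of cyclopentyl on the same carbonyl carbon (a 3.4-fold lower number from compound 3 to compound 4 (0.54 log units; beyond the scatter)), so the kind of ring on this carbon matters and not merely the presence of a ring. The larger aromatic group also improves on the small 1-fluoroethyl carbamate (a 3.1-fold lower number from compound 1 to compound 4 (0.49 log units; beyond the scatter)), while the comparison with the fluorine-rich 1-(trifluoromethyl)cyclobutyl carbamate stays inside the usual scatter (a 1.5-fold higher number from compound 2 to compound 4 (0.17 log units; within the scatter)), which shows that a low number at this position does not depend on a group carrying fluorine. Nothing available here explains why these groups differ in this way.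

The compounds shown leave open whether the gain comes from the oxadiazole ring itself or from the isopropyl group it carries. A methyl or a tert-butyl group in place of that isopropyl, or a 1,3,4-oxadiazole ring in place of the 1,2,4-oxadiazole ring, would begin to separate these two contributions.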